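The source may hold more compounds than are shown below. What is called first, only, known or untested is meant among the compounds shown, and "the series" means these compounds.

For the measured compounds named here, only two compounds of this family have numbers so far. In an ADME assay on L6 cells (Rattus norvegicus) for cytotoxicity, read by resazurin assay, with a stated time of 70 h (a lower number here means a stronger inhibitor, a higher number a weaker inhibitor), compound 1 `COc1ccc(CN2c3ccc(O)cc3C(C)=CC2(C)C)cc1` gives 6200 nM and compound 2 `CC(=O)Oc1ccc2c(c1)C(C)=CC(C)(C)N2Cc1ccc(C(F)(F)F)cc1` gives 14000 nM. Compound 2 therefore holds the higher of the two numbers, and the gap lies beyond the usual scatter of repeat measurements. These two compounds differ in more than one place, so their gap cannot be pinned on any single group.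

Compound 3 `COc1ccc(CN2c3ccc(OC(C)=O)cc3C(C)=CC2(C)C)cc1` differs from compound 2 in one place, with methoxy in place of trifluoromethyl on an aromatic carbon. Going by the values given here, no measured pair shows this swap alone, so any forecast rests on thin evidence. Among the compounds with values here, the only guide is that compound 1, which also carries methoxy, reads 6200 nM. That points to a slight lean toward a lower number in this assay, though not to a step clearly beyond the scatter. The expected change is small, a 1.4-fold lower number from compound 2 to compound 3 (0.15 log units; within the scatter). For compound 3 the estimated value is 10000 nM, with an expected range from 3500 nM to 30000 nM.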

Compound 3, half-maximal inhibitory concentration: 15000 nM
For compound 3 the middle estimate is 1.5-fold (0.18 log units) below the measured one; measured number inside the range.
By their numbers in this assay, from the lowest: compound 1; then compounds 2 and 3 (each within the scatter of the next).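

In this assay, placing methoxy in place of trifluoromethyl on an aromatic carbon, para to a large group, gives a 1.1-fold higher number from compound 2 to compound 3 (0.03 log units; within the scatter), so at this position and with acetyl on the oxygen, these two groups cannot be told apart, even though only methoxy counts a hydrogen-bond acceptor. Compounds 1 and 2 differ in more than one place, but compounds 1 and 3 now isolate a single change: acetyl in place of hydrogen on an oxygen on an aromatic ring gives a 2.4-fold higher number from compound 1 to compound 3 (0.38 log units; beyond the scatter), a modest step that is the only one here beyond the usual scatter. Nothing measured on these compounds accounts for either result.

From the compounds shown here alone, each change rests on a single pair, so it remains open whether methoxy and trifluoromethyl would also read alike when the oxygen carries hydrogen rather than acetyl, and whether acetyl would give a similar step with trifluoromethyl on the aromatic carbon. Going by these compounds, it also remains open how an amine or a carboxylic acid on that aromatic carbon, or a longer chain in place of acetyl on the oxygen, would read in this assay.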